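This account rests on a few compounds, and the source may have more. Where it says the series, first, only, none or still open, it means among the compounds named here.

Of the compounds shown here, three built on one shared core have been measured in an assay on NIH3T3 cells for inhibition of Sonic hedgehog protein (Mus musculus), read by a luciferase reporter, with a stated time of 48 h; a lower number here means a stronger inhibitor, a higher number a weaker inhibitor. Compound 1 `Cc1cnc(Nc2ccc3[nH]ncc3c2)nc1-c1ccc(OC(F)(F)F)cc1` gives 125 nM. Compound 2 `Cc1ccccc1C(=O)Nc1ccc(Nc2ncc(C)c(-c3ccc(OC(F)(F)F)cc3)n2)cc1` gives 42.1 nM. Compound 3 `Cc1cnc(Nc2ccc(C(=O)Nc3c(C)cccc3C)cc2)nc1-c1ccc(OC(F)(F)F)c(F)c1` gives 159 nM, the highest of the three numbers; its gap to compound 1 lies within the usual scatter, while its gap to compound 2 lies beyond it, so compound 2 sits at a clearly lower number than compound 3.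

Compound 4 `Cc1cnc(Nc2ccc(C(=O)Nc3c(C)cccc3C)cc2)nc1-c1cnn(C)c1` has not yet been measured. It differs from compound 3 in a single place: 1-methyl-1H-pyrazol-4-yl in place of 3-fluoro-4-(trifluoromethoxy)phenyl on an aromatic carbon. Within the data shown here, no pair of measured compounds shows a change of this kind, so there is no measured step to lean on; the 3-fluoro-4-(trifluoromethoxy)phenyl group gives way to the much smaller 1-methyl-1H-pyrazol-4-yl group, and the data say nothing about what such a swap does to the read-out. The step expected here is a 2.8-fold higher number from compound 3 to compound 4 (0.45 log units; beyond the scatter), a moderate rise in the number that would go beyond the scatter but remains uncertain in size. The estimate for compound 4 in this assay is 450 nM, with a range from 120 nM to 2000 nM.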

Compound 4, half-maximal inhibitory concentration: 10.6 nM
Estimate against measurement, compound 4: 42-fold (1.63 log units) above, outside the stated range (below it).
By their numbers in this assay, from the lowest: compound 4; then compound 2; then compounds 1 and 3 (each within the scatter of the next).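

In this assay, among these compounds, replacing 3-fluoro-4-(trifluoromethoxy)phenyl with 1-methyl-1H-pyrazol-4-yl gives a 15-fold lower number from compound 3 to compound 4 (1.18 log units; beyond the scatter), a large step and the first measured change at this aromatic carbon next to the ring nitrogen. The earlier compounds shown here all carry a phenyl ring with a trifluoromethoxy group here, whereas this result shows that a smaller five-membered aromatic ring with 2 hetero atoms, and no fluorine, goes with a much lower number. Nothing available here explains why the number falls.

From the compounds shown here alone, this is a single step on a single background, so it remains open whether the same swap would lower the number alongside other groups elsewhere on the shared core. Also open, going by these compounds, is how the number would respond at this position to an unmethylated pyrazole, a pyridine ring or an amine such as morpholine.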